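Swapping the aryl group on the ether oxygen of compound 2

A few compounds are considered here, and "the series" means these few. Any claim that something is new, unique, unknown or untested is made for them only; others in the source may bear on it.

Compound 1, `O=C(Nc1cccc(C(F)(F)F)c1)N[C@H]1CC[C@H](O)CC1` — in a functional assay on CRL2813 cells (Homo sapiens) for cytotoxicity, read by sulforhodamine B assay, with a stated time of 5 days (a lower number here means a stronger inhibitor, a higher number a weaker inhibitor), compound 1 reports only a limit of > 20000 nM.
Compound 2, `O=C(Nc1cccc(C(F)(F)F)c1)N[C@H]1CC[C@H](Oc2ccccc2C(F)(F)F)CC1` — in this assay compound 2 gives 1400 nM.

Going by the values given here, compound 2 holds the only numerical value in this assay; the other result is a limit. Among the compounds with values here, the one measured step, an at least 14-fold lower number from compound 1 to compound 2 (1.15 log units; beyond the scatter), shows that placing the 2-(trifluoromethyl)phenyl on the oxygen carries the series from a limit to a number (the limit of > 20000 nM in this assay, at which 1 of the 2 values shown sits).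

Compound 3, `O=C(Nc1cccc(C(F)(F)F)c1)N[C@H]1CC[C@H](Oc2cccc(F)c2)CC1`, keeps that oxygen occupied and changes only the group on it: 3-fluorophenyl in place of 2-(trifluoromethyl)phenyl on an oxygen on a saturated carbon. Within the data shown here, no measured step compares two different groups on this oxygen, so the step from compound 1 to compound 2 speaks only to the presence of a group there, not to which one. With both compounds 2 and 3 carrying an aromatic ring on the oxygen, the estimated step is a 1.8-fold higher number from compound 2 to compound 3 (0.25 log units; within the scatter), a modest expected change within or near the scatter. Compound 3 is therefore expected to give about 2500 nM in this assay, estimated between 800 nM and 8000 nM.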

Compound 3, half-maximal inhibitory concentration: 2400 nM
Estimate against measurement, compound 3: 1.0-fold (0.02 log units) above; low and high end bracket the measured number.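

In this assay, a second aromatic group on the oxygen also moves the series from a limit to a number, with an at least 8.3-fold lower number from compound 1 to compound 3 (0.92 log units; beyond the scatter). The effect first seen with compound 2 is therefore not confined to 2-(trifluoromethyl)phenyl. Exchanging that group for 3-fluorophenyl gives a 1.7-fold higher number from compound 2 to compound 3 (0.23 log units; within the scatter), so this assay does not separate the two groups, and compound 1, with hydrogen on the oxygen, remains the only result that is a limit: the limit of > 20000 nM in this assay, at which 1 of the 3 values shown sits.

The compounds shown leave open whether an aromatic ring is needed on this oxygen at all, or whether a methyl or cyclohexyl group there would give a similar result. They also leave open how the number would respond to an aryl group carrying an amine or a carboxylic acid.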